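Hydroxy analog of compound 3: expected growth inhibition

The source may hold more compounds than are shown below. What is called first, only, known or untested is meant among the compounds shown, and "the series" means these compounds.

Among the measured compounds shown here, in a functional assay on NCI-H322M cells (Homo sapiens) for inhibition, read by sulforhodamine B assay, with a stated time of 48 h (a lower number here means a stronger inhibitor of growth, a higher number a weaker inhibitor of growth), every compound of this series so far returns only a limit. Compound 1 `O=C(Nc1cccc(-n2cc(-c3ccncc3)c(-c3ccc(Cl)c(O)c3)n2)c1)Nc1cccc(C(F)(F)F)c1` gives a limit of > 32500 nM. Compound 2 `COc1cc(-c2nn(-c3cccc(NC(=O)c4cccc(C(F)(F)F)c4)c3)cc2-c2ccncc2)ccc1Cl` gives a limit of > 50000 nM. Compound 3 `COc1cc(-c2nn(-c3cccc(NC(=O)Nc4ccc(Cl)c(Cl)c4)c3)cc2-c2ccncc2)ccc1Cl` gives a limit of > 50000 nM. Compound 3 thus stands on a limit, as do the other two values, with one at the limit of > 32500 nM in this assay, at which 1 of the 3 values shown sits, and two at the limit of > 50000 nM in this assay, at which 2 of the 3 values shown sit.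

For the measured compounds named here, the one single-place step among the measured compounds, a step that the two limits leave unreadable from compound 2 to compound 3, runs between two limits and its size cannot be read. Compound 4 `O=C(Nc1cccc(-n2cc(-c3ccncc3)c(-c3ccc(Cl)c(O)c3)n2)c1)Nc1ccc(Cl)c(Cl)c1` differs from compound 3 by hydrogen in place of methyl on an oxygen on an aromatic ring, read one bond further out as methoxy to hydroxy; 4-chloro-3-methoxyphenyl to 4-chloro-3-hydroxyphenyl. Going by the values given here, no measured step covers this change. Compound 1 carries the same hydroxy group with a different urea substituent, and its value and that of compound 3 are both limits, so no difference between them can be read in size or direction.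

With all values at limits, the step expected in this assay for compound 4 is a number no higher from compound 3 to compound 4 (the limit leaves the size open), essentially none beyond the scatter. Compound 4 is expected to give 50000 nM, within 20000 nM to 120000 nM, and most likely to be reported again as a limit.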

Compound 4, concentration for total growth inhibition: > 32500 nM
Compound 4 ended at the assay's limit; the forecaster's own chance of this, stated with the estimate: 85%; the middle value does not contradict the limit.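

In this assay compound 4 gives > 32500 nM, which is a limit. The pairs compound 3 with compound 4 and compound 1 with compound 4 each join two limits, and no step can be read from either. The compounds shown leave open whether methoxy to hydroxy, or 3-(trifluoromethyl)phenyl to 3,4-dichlorophenyl, changes growth inhibition at all.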